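The compounds below may be only part of what the source reports. "The series", "measured", "known", "first", "only" and "open" are said of these compounds alone.

Notes on the series. In a functional assay on L1210 cells (Mus musculus) for inhibition, read by cell counting, with a stated time of 2 days (on this read-out lower numbers stand for stronger inhibition and higher numbers for weaker inhibition), compound 1 `CCc1ccc(-c2nn3cc(-c4cccc(N)c4)nc3s2)cc1` gives 6000 nM. In this assay, going by the values given here, compound 2 `C=C(Br)C(=O)Nc1cccc(-c2cn3nc(Cc4cccc(OC)c4)sc3n2)c1` gives 2000 nM, the lowest of the two numbers so far, with compound 1 standing higher, beyond the scatter. Compound 3 `C=C(Br)C(=O)Nc1cccc(-c2cn3nc(-c4ccc(OC)cc4)sc3n2)c1` is not yet measured. Its change from compound 2: 4-methoxyphenyl in place of 3-methoxybenzyl on an aromatic carbon. Among the compounds with values here, no measured pair shows this change, so the step is expected to stay within the scatter, with no clear direction: a 1.3-fold higher number from compound 2 to compound 3 (0.10 log units; within the scatter). Compound 3 is therefore estimated at 2500 nM, with a range from 800 nM to 8000 nM.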

Compound 3, half-maximal inhibitory concentration: 940 nM
The estimate for compound 3 lay 2.7-fold (0.42 log units) above the measured number, and the stated range covers the measured number.
By their numbers in this assay, from the lowest: compound 3; then compound 2; then compound 1.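

With the group on this aromatic carbon, next to the ring sulfur, changed from 3-methoxybenzyl to 4-methoxyphenyl, this assay shows a 2.1-fold lower number from compound 2 to compound 3 (0.33 log units; beyond the scatter) as the first step read at this position. The number here therefore responds to the group carried, though the step is modest. No measurement at hand bears on the reason for the step.

The change replaces the benzyl with a phenyl and shifts the methoxy in one move, so the two stay unseparated. Going by these compounds, how a plain phenyl, an amine or a carboxylic acid would read at this carbon remains open.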